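Chloro added on the nitrogen-containing ring: cytotoxicity notes

This account rests on a few compounds, and the source may have more. Where it says the series, first, only, none or still open, it means among the compounds named here.

Compound 1 `COc1cccc(S(=O)(=O)/C=C/c2ccccn2)c1` is the reference of this set. In an ADME assay on BV-2 cells (Mus musculus) for cytotoxicity, with a stated time of 24 h, tested at 10 uM (a lower number here means a stronger effect, a higher number a weaker effect of the compound at the concentration tested), compound 1 gives 100%. Compound 2 `COc1cccc(S(=O)(=O)/C=C/c2ccc(Cl)cn2)c1` carries the change chloro in place of hydrogen on an aromatic carbon and in this assay compound 2 gives 100%, so that no change at the digits printed from compound 1 to compound 2 (within the scatter). Compound 3 `COc1ccccc1S(=O)(=O)/C=C/c1cccnc1Cl` has a different core; the difference between the two cores is not broken down here. In this assay compound 3 gives 99.7%. Compound 4 `COc1ccccc1S(=O)(=O)/C=C/c1ccc(Cl)nc1Cl` is not yet measured and differs from compound 3 by chloro in place of hydrogen on an aromatic carbon, the same kind of change as from compound 1 to compound 2, though here the entering group sits next to the ring nitrogen and meta to a chloro group, whereas in compound 2 it sits two atoms from the ring nitrogen. Because no change at the digits printed from compound 1 to compound 2 (within the scatter), the expected step is a number 0.7 percentage points lower from compound 3 to compound 4 (within the scatter). For compound 4 in this assay the estimated value is 99%, between 88% and 104%.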

Compound 4, a percentage reported as activity, at one concentration (the size of the read-out at that concentration, not a potency): 100%
Estimate against measurement, compound 4: 1 percentage points below, within the range that was stated.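

In this assay, chloro in place of hydrogen on an aromatic carbon gives a number 0.3 percentage points higher from compound 3 to compound 4 (within the scatter). Set beside the earlier step, the change carries from one core to the other with no difference beyond the scatter: the same change on two cores in this assay, no change at the digits printed (within the scatter) from compound 1 to compound 2 and a number 0.3 percentage points higher (within the scatter) from compound 3 to compound 4, 0.3 percentage points apart, within the scatter of two such steps. This holds for two examples of the change, at different places on the ring and at a single concentration in a single assay, so it does not show that chloro would be equally without effect at other places, on other cores or in other read-outs.

From the compounds shown here alone, whether a group other than chloro, such as an amine or a carboxylic acid, on the same ring would also leave this read-out flat stays open. So does the effect of these compounds at higher concentrations.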